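The source may report more compounds than this note shows. Statements on the series, on what has been measured and on what is new or still open speak of the compounds shown alone.

Compound 1 `CC(=O)N1c2ccccc2CCC1C(=O)Nc1ccccc1O` gives the higher of the two numbers in a functional assay on NCI-H23 cells (Homo sapiens) for cytotoxicity, read by sulforhodamine B assay, with a stated time of 72 h (a lower number here means a stronger inhibitor of growth, a higher number a weaker inhibitor of growth), at 65700 nM; compound 2 `CCCCCCCCC(=O)N1c2ccccc2CCC1C(=O)Nc1cc(C(F)(F)F)cc(C(F)(F)F)c1` gives 3230 nM, a lower number beyond the scatter, though compound 2 differs from compound 1 in more than one place. Compound 3 `O=C(Nc1ccccc1O)C1CCc2ccccc2N1C(=O)c1ccccc1` differs from compound 1 only by phenyl in place of methyl on a carbonyl carbon, that is, acetyl to benzoyl. For the measured compounds named here, no single step of this kind has been measured here, so little supports a firm expectation; a modest step toward a lower number is expected, a 2.2-fold lower number from compound 1 to compound 3 (0.34 log units; beyond the scatter). Compound 3 is accordingly estimated at 30000 nM, within 8000 nM to 100000 nM.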

Compound 3, concentration for 50% growth inhibition: 3490 nM
The estimate for compound 3 lay 8.6-fold (0.93 log units) above the measured number; measured number outside the range, below it.
By their numbers in this assay, from the lowest: compounds 2 and 3 (each within the scatter of the next); then compound 1.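

For the compounds shown here, replacing methyl with phenyl on the carbonyl carbon gives a 19-fold lower number from compound 1 to compound 3 (1.27 log units; beyond the scatter) in this assay, the first single change that can be read in this set. It shows that the group on this carbonyl carbon can strongly change the number, which the earlier pair of compounds, differing in more than one place, could not show. Nothing available explains the size of this step. On these data alone, whether the step depends on the aromatic ring or on the added carbons remains open, and a cyclohexyl group or a butyl chain here would separate the two. As far as these compounds go, a methoxy group or a chlorine on the phenyl also remains open.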